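Compound 3 to compound 4: 2-phenylethenyl on the carbonyl

A few compounds are considered here, and "the series" means these few. Any claim that something is new, unique, unknown or untested is made for them only; others in the source may bear on it.

In a functional assay on A549 cells (Homo sapiens) for cytotoxicity, read by resazurin assay, with a stated time of 72 h (a lower number here means a stronger inhibitor, a higher number a weaker inhibitor), compound 3 (`COCOc1cc(OC)cc(OC)c1C(C)=O`) gives 16900 nM. Compound 2 (`COc1cc(OC)c(C(=O)/C=C/c2ccccc2)c(OC)c1Cc1ccccc1O`) gives 9300 nM, and compound 1 (`COc1cc(OC)c(C(=O)/C=C/c2ccccc2)c(OC)c1`) gives 4300 nM. The gap between compound 3 and compound 2 lies within the scatter, while the gap between compound 3 and compound 1 lies beyond it. Compound 4 (`COCOc1cc(OC)cc(OC)c1C(=O)/C=C/c1ccccc1`) differs from compound 3 by 2-phenylethenyl in place of methyl on a carbonyl carbon. Going by the values given here, no measured step covers this change. The only one, a 2.2-fold higher number from compound 1 to compound 2 (0.34 log units; beyond the scatter), is modest and concerns 2-hydroxybenzyl in place of hydrogen on an aromatic carbon. Compound 1, which also carries 2-phenylethenyl on the carbonyl carbon, gives 4300 nM, so a value near it is expected. A lower number is expected, a 3.1-fold lower number from compound 3 to compound 4 (0.49 log units; beyond the scatter). Compound 4 is estimated at 5500 nM, with an expected range of 2200 nM to 13000 nM.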

Compound 4, half-maximal inhibitory concentration: 3500 nM
Compound 4: middle estimate off by 1.6-fold (0.20 log units), on the high side, within the range that was stated.
By their numbers in this assay, from the lowest: compounds 4 and 1 (each within the scatter of the next); then compounds 2 and 3 (each within the scatter of the next).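

In this assay, the carbonyl carbon proves responsive: 2-phenylethenyl in place of methyl gives the step of a 4.8-fold lower number from compound 3 to compound 4 (0.68 log units; beyond the scatter), which is beyond the scatter. With 2-phenylethenyl present, methoxy in place of hydrogen on the saturated chain carbon bound to an oxygen on an aromatic ring gives the step of a 1.2-fold lower number from compound 1 to compound 4 (0.09 log units; within the scatter), which stays within the scatter. Nothing available explains either step.

Still open, on these data alone, is whether the double bond or the aromatic ring of 2-phenylethenyl accounts for the first step. Also open, as far as these compounds go, is how an amine or a longer saturated chain on the carbonyl carbon would read in this assay.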